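This account rests on a few compounds, and the source may have more. Where it says the series, first, only, none or still open, it means among the compounds named here.

Compound 2 `Cc1ccc(S(=O)(=O)c2cc3cnc(Nc4cnc5c(c4)CC(=O)N5)nc3n(C)c2=O)cc1` is measured in a functional assay on K562 cells (Homo sapiens) for inhibition, read by trypan blue exclusion, with a stated time of 72 h (a lower number here means a stronger inhibitor, a higher number a weaker inhibitor), where compound 2 gives 15000 nM, the higher of the two numbers recorded; compound 1 `Cn1c(=O)c(S(=O)(=O)c2ccc(OC(=O)CCCCC3SCC4NC(=O)NC43)cc2)cc2cnc(Nc3ccc4[nH]ccc4c3)nc21`, which carries a different group on the sulfonyl and a different group on the aromatic amine, gives 600 nM in this assay. Compound 3 `Cc1ccc(S(=O)(=O)c2cc3cnc(Nc4cccc5[nH]ccc45)nc3n(C)c2=O)cc1` is not yet measured. It differs from compound 2 in one place: a group of 9 heavy atoms (8 carbon, 1 nitrogen; one five-membered aromatic ring with 1 hetero atom, one six-membered aromatic ring of carbon only) in place of a group of 10 heavy atoms (7 carbon, 2 nitrogen, 1 oxygen; one five-membered non-aromatic ring with 1 hetero atom, one six-membered aromatic ring with 1 hetero atom), on a nitrogen on an aromatic ring. Going by the values given here, no step between measured compounds with this change exists, so the size is uncertain; a lowering beyond the scatter is expected, with the step from compound 2 to compound 3 estimated as a 5.0-fold lower number from compound 2 to compound 3 (0.70 log units; beyond the scatter). Compound 3 is expected to give 3000 nM in this assay, within 600 nM to 15000 nM.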

Compound 3, half-maximal inhibitory concentration: 5000 nM
The estimate for compound 3 lay 1.7-fold (0.22 log units) below the measured number; measured number inside the range.
By their numbers in this assay, from the lowest: compound 1; then compound 3; then compound 2.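

On a nitrogen on an aromatic ring, with the rest of the molecule unchanged, 1H-indol-4-yl in place of the group in compound 2 gives a 3.0-fold lower number from compound 2 to compound 3 (0.48 log units; beyond the scatter) in this assay. Going by these compounds alone, this is the first one-place step at this position, and it shows that the group here can shift the number beyond the scatter, even though both groups carry 1 hydrogen-bond donor. No measurement available bears on why the number falls. On these data alone, whether a plain phenyl or a morpholine-bearing phenyl on this nitrogen would give a lower number stays open. So does whether this step keeps its size with the sulfonyl group of compound 1.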